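The source may hold more compounds than are shown below. What is called first, only, known or untested is meant among the compounds shown, and "the series" means these compounds.

Measured so far:
- compound 1, `OCCCc1cn[nH]c1`: 560 nM in an assay for inhibition of alcohol dehydrogenase (Equus caballus), read by spectrophotometry, in the presence of a further agent that is not named here; on this read-out lower numbers stand for tighter binding and higher numbers for weaker binding
- compound 2, `OCc1cc[nH]n1`: 150000 nM in this assay
- compound 3, `OCc1cn[nH]c1`: 3600 nM in this assay

Among these three, compound 2 gives the highest number in this assay, that is the weakest binding. Compound 3 comes nearest, with a lower number, and compound 1 lies furthest, lower still; both gaps are beyond the usual scatter. Compound 4, `OCCc1cc[nH]n1`, has not been measured. It differs from compound 2 in one place: hydroxymethyl in place of hydroxy on a saturated chain carbon bound to an aromatic carbon.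

For the measured compounds named here, one measured step bears on this change. The step of a 6.4-fold higher number from compound 1 to compound 3 (0.81 log units; beyond the scatter) shows that, on the shared core of those two compounds, shortening the chain that carries the hydroxy raised the number. The change from compound 2 to compound 4 runs the other way and by a single carbon, so a lower number is expected, with a step smaller than that one. Compound 4 is therefore expected to give 60000 nM, within 20000 nM to 150000 nM. The expected step is a 2.5-fold lower number from compound 2 to compound 4 (0.40 log units; beyond the scatter).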

Compound 4, dissociation constant: 170000 nM
Beside the measured number, compound 4's estimate is 2.8-fold (0.45 log units) below it, outside the stated range (above it).
By their numbers in this assay, from the lowest: compound 1; then compound 3; then compounds 2 and 4 (each within the scatter of the next).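

On the core of compound 2, putting hydroxymethyl in place of hydroxy on a saturated chain carbon bound to an aromatic carbon gives a 1.1-fold higher number from compound 2 to compound 4 (0.05 log units; within the scatter) in this assay, so the two numbers cannot be told apart. The chain length that mattered on the other core, with a 6.4-fold higher number from compound 1 to compound 3 (0.81 log units; beyond the scatter), therefore shows no measurable effect for this change on this core, and both compounds here stay among the highest numbers in the set. Nothing shown here explains the difference between the two cores.

The compounds shown leave open whether a longer chain carrying the hydroxy would lower the number on the core of compound 2, as the longest chain among these compounds goes with the lowest number on the other core. They also leave open whether an amine or a carboxylic acid in place of the hydroxy would change the number at this position.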